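The source may hold more compounds than are shown below. What is called first, only, known or untested is meant among the compounds shown, and "the series" means these compounds.

Measured in an ADME assay on H9c2 cells (Rattus norvegicus) for cytotoxicity; on this read-out higher numbers stand for weaker inhibition and lower numbers for stronger inhibition:
compound 1 `CC(C)C(=O)Nc1nc2cc(F)c(C(F)(F)F)cc2s1`: > 50000 nM
compound 2 `CC(C)(F)C(=O)Nc1nc2ccc(C(F)(F)F)cc2s1`: > 50000 nM

Compound 2 reads > 50000 nM, which is a limit and not a number. Compound 1 reads > 50000 nM, likewise a limit. Together they give (the limit of > 50000 nM in this assay, at which 2 of the 2 values shown sit).

Compound 3 `CC(C)(F)C(=O)Nc1nc2cc(F)c(C(F)(F)F)cc2s1` carries fluoro in place of hydrogen on an aromatic carbon of compound 2, ortho to a trifluoromethyl group: fluoro in place of hydrogen on an aromatic carbon. Within the data shown here, no measured step is available for this change. In this assay no step beyond the scatter is expected, and the read-out of compound 3 is expected to remain a limit because of the limit of > 50000 nM in this assay, at which 2 of the 2 values shown sit. The estimated step is a number no higher from compound 2 to compound 3 (the limit leaves the size open). Compound 3 is estimated at 50000 nM, with an expected range of 25000 nM to 100000 nM.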

Compound 3, half-maximal inhibitory concentration: > 50000 nM
Compound 3 gave a limit, no number; the forecaster's own chance of this, stated with the estimate: 85%; the middle value sits exactly at the limit.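

No step can be read among compound 1, compound 2 and compound 3, because all three values are limits: the limit of > 50000 nM in this assay, at which 3 of the 3 values shown sit.

The compounds shown leave open whether either fluoro replacement changes the read-out at all.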